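Phosphate series: removing one phosphate group from compound 2

The compounds below may be only part of what the source reports. "The series", "measured", "known", "first", "only" and "open" are said of these compounds alone.

Compound 1 `O=P(O)(O)Oc1cc(OP(=O)(O)O)cc(OP(=O)(O)O)c1` gives 11300 nM in an assay on cells for displacement of a labelled ligand from phosphatidylinositol 3,4,5-trisphosphate 5-phosphatase 2 (Homo sapiens), read by fluorescence polarization; on this read-out higher numbers stand for weaker inhibition and lower numbers for stronger inhibition. Among the measured compounds shown here, compound 2 `O=P(O)(O)Oc1cc(OP(=O)(O)O)c(OP(=O)(O)O)c(OP(=O)(O)O)c1` gives 1010 nM in this assay and so stands at the lowest of the two numbers measured, the one step recorded being an 11-fold lower number from compound 1 to compound 2 (1.05 log units; beyond the scatter). Compound 3 `O=P(O)(O)Oc1cccc(OP(=O)(O)O)c1OP(=O)(O)O` has not yet been measured. It differs from compound 2 by a hydrogen atom in place of a group of 5 heavy atoms (4 oxygen, 1 phosphorus; no ring), on an aromatic carbon. For the measured compounds named here, the only measured step that bears on this change is the one from compound 1 to compound 2, where a group of the same kind was added and the number fell by a large margin; the change to compound 3 runs the other way, so a rise of roughly that size is expected, although compound 3 is not compound 1 and the three remaining groups are arranged differently, which leaves room for a smaller rise. The step to compound 3 is therefore estimated as a 5.9-fold higher number from compound 2 to compound 3 (0.77 log units; beyond the scatter), and compound 3 is expected to give about 6000 nM, within 2000 nM to 20000 nM.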

Compound 3, half-maximal inhibitory concentration: 14200 nM
Estimate against measurement, compound 3: 2.4-fold (0.37 log units) below; the range from low to high includes it.
By their numbers in this assay, from the lowest: compound 2; then compounds 1 and 3 (each within the scatter of the next).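

Taking the phosphate group off the aromatic carbon that is meta to two groups of 5 heavy atoms each and para to a group of 5 heavy atoms costs a large step in this assay: a 14-fold higher number from compound 2 to compound 3 (1.15 log units; beyond the scatter). The earlier step, an 11-fold lower number from compound 1 to compound 2 (1.05 log units; beyond the scatter), concerned a different carbon, so compound 2 now loses its lower number on either of two separate single removals, and the group on this carbon is not dispensable in the context of compound 2. No independent measurement accounts for the size of this step. The compounds shown leave open whether a carboxylic acid, a sulfate or a hydroxyl group on this carbon would retain the number of compound 2. They also leave open whether a longer chain carrying the phosphate group would do so.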